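Adding a Second Methoxy Group: Compound 3 to Compound 4

The compounds below may be only part of what the source reports. "The series", "measured", "known", "first", "only" and "open" are said of these compounds alone.

Measured so far:
- compound 1, `COc1cc(-n2c(-c3ccccc3)csc2=S)cc(OC)c1OC`; in a functional assay on MCF7 cells (Homo sapiens) for cytotoxicity, read by MTT assay, with a stated time of 48 h (on this read-out lower numbers stand for stronger inhibition and higher numbers for weaker inhibition), compound 1 gives > 100 ug/mL, which is a limit of the assay rather than a number.
- compound 2, `COc1cc(-n2c(-c3ccc(Cl)cc3Cl)csc2=S)cc(OC)c1OC`; in this assay compound 2 gives 23.6 ug/mL.
- compound 3, `COc1ccc(-n2c(-c3ccccc3)csc2=S)cc1`; in this assay compound 3 gives 88.5 ug/mL.

Among the two real numbers, compound 3 stands highest, meaning the weakest inhibition measured; its nearest neighbour is compound 2, which sits a distance below it that lies beyond the usual scatter. Compound 1 sits at the limit of > 100 ug/mL in this assay, at which 1 of the 3 values shown sits, and so returns no number at all.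

The step under consideration leads from compound 3 to compound 4, `COc1ccc(-n2c(-c3ccccc3)csc2=S)cc1OC`, and consists of methoxy in place of hydrogen on an aromatic carbon. Among the measured compounds shown here, the only measured step, an at least 4.2-fold lower number from compound 1 to compound 2 (0.62 log units; beyond the scatter), exchanges one aromatic ring for another and touches no methoxy group, so it says nothing about this change. For the measured compounds named here, no measured pair differs by a single methoxy group. Compound 1 carries three methoxy groups on its ring and reports only a limit. Compound 3 carries one and reports a number near the top of the measured range.

Going by the values given here, with no guiding step, compound 4 is expected to give about 100 ug/mL, with a likely range from 45 ug/mL to 220 ug/mL. The expected step of a 1.1-fold higher number from compound 3 to compound 4 (0.05 log units; within the scatter) is estimated to be none beyond the scatter, with a real chance that only a limit is reported.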

Compound 4, half-maximal inhibitory concentration: 17.6 ug/mL
For compound 4 the middle estimate is 5.7-fold (0.75 log units) above the measured one, and the stated range ends above it.
By their numbers in this assay, from the lowest: compounds 4 and 2 (each within the scatter of the next); then compound 3. At a limit, above all of these: compound 1.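

In this assay, methoxy in place of hydrogen on an aromatic carbon, ortho to a methoxy group and meta to a large group, gives a 5.0-fold lower number from compound 3 to compound 4 (0.70 log units; beyond the scatter). Among the compounds shown here, this is the first measured step that changes only a methoxy group, and it shows that this position on the ring can respond to such a change, with the number moving toward stronger inhibition. The other new step shows that adding methoxy groups does not simply keep helping: hydrogen in place of methoxy gives an at least 5.6-fold lower number from compound 1 to compound 4 (0.75 log units; beyond the scatter), so here a methoxy group is better absent, and compound 1 reports a limit rather than a number, which makes this step a bound and not a measured size: the limit of > 100 ug/mL in this assay, at which 1 of the 4 values shown sits.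

The compounds shown leave open whether a hydroxyl, an amine or an ethoxy group on the same carbon would give a similar step, so the change cannot yet be tied to methoxy in particular. They also leave open whether the added methoxy group would act in the same way with the 2,4-dichlorophenyl of compound 2 in place of phenyl, and they offer no explanation for either step.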